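Moving the bromine on the phenyl ring: cytotoxicity outlook

A few compounds are considered here, and "the series" means these few. Any claim that something is new, unique, unknown or untested is made for them only; others in the source may bear on it.

The series shares one core, seen in compound 1 `N/C(=N/NC(CC(=O)c1ccc(-n2ccnc2)cc1)c1ccccc1Cl)c1ccccn1`, compound 2 `N/C(=N/NC(CC(=O)c1ccc(-n2ccnc2)cc1)c1cccc(F)c1)c1ccccn1` and compound 3 `N/C(=N/NC(CC(=O)c1ccc(-n2ccnc2)cc1)c1cccc(Br)c1)c1ccccn1`. In an ADME assay on Vero cells (Chlorocebus sabaeus) for cytotoxicity, read by MTT assay, with a stated time of 72 h (on this read-out lower numbers stand for higher toxicity in this test and higher numbers for lower toxicity in this test), compound 1 gives 53200 nM, compound 2 gives 26500 nM and compound 3 gives 51300 nM. Compound 3 stands second highest of the three numbers; its nearest neighbour is compound 1, with a 1.0-fold lower number from compound 1 to compound 3 (0.02 log units; within the scatter), and its furthest is compound 2, with a 1.9-fold higher number from compound 2 to compound 3 (0.29 log units; within the scatter), so all three sit within the scatter of one another. The step from compound 1 to compound 2, a 2.0-fold lower number from compound 1 to compound 2 (0.30 log units; within the scatter), is likewise within the scatter.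

Compound 4 `N/C(=N/NC(CC(=O)c1ccc(-n2ccnc2)cc1)c1ccc(Br)cc1)c1ccccn1` differs from compound 3 only in that (4-bromophenyl in place of 3-bromophenyl on a saturated chain carbon bound to an amine nitrogen and a saturated chain carbon). Among the measured compounds shown here, none of the measured steps moves the same halogen from one ring position to another; the two steps that change the ring substituent together with its position, and the one that changes only the halogen, all stayed within the scatter in this assay. There is therefore no basis to expect a step in this assay beyond the scatter in either direction.

For compound 4 the estimated step from compound 3 is a 1.0-fold lower number from compound 3 to compound 4 (0.01 log units; within the scatter), and in this assay compound 4 is expected to give about 50000 nM, within a range of 22000 nM to 115000 nM.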

Compound 4, half-maximal cytotoxic concentration: 298000 nM
For compound 4 the middle estimate is 6.0-fold (0.78 log units) below the measured one; measured number outside the range, above it.
By their numbers in this assay, from the lowest: compounds 2, 3 and 1 (each within the scatter of the next); then compound 4.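

In this assay, 4-bromophenyl in place of 3-bromophenyl on the saturated chain carbon bound to an amine nitrogen and a saturated chain carbon gives a 5.8-fold higher number from compound 3 to compound 4 (0.76 log units; beyond the scatter), so the place of the bromine on the ring matters here even though the atoms stay the same. The other two steps to this group are also beyond the scatter, at a 5.6-fold higher number from compound 1 to compound 4 (0.75 log units; beyond the scatter) and an 11-fold higher number from compound 2 to compound 4 (1.05 log units; beyond the scatter), which sets it apart from the three earlier aryl groups, all within the scatter of one another, and makes it the least toxic in this test of the four. Nothing available bears on why this one change in ring position has so much larger an effect than the earlier steps.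

The compounds shown leave open whether the higher number belongs to bromine in particular or would also appear with 4-chlorophenyl, 4-fluorophenyl or 4-methoxyphenyl at this place. They also leave open where 2-bromophenyl would fall, which would complete the comparison of bromine's ring positions on this carbon.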